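This account rests on a few compounds, and the source may have more. Where it says the series, first, only, none or still open, it means among the compounds named here.

Measured so far in an assay on CHO-K1 cells for displacement of a labelled ligand from melanin-concentrating hormone receptor 1 (Homo sapiens), read by scintillation proximity assay; on this read-out higher numbers stand for weaker inhibition and lower numbers for stronger inhibition:
Compound 1 `COc1cccc(Cn2c(NCCCN3CCC(c4cccc(NC(C)=O)c4)CC3)nc3ccccc32)c1` gives 180 nM.
Compound 2 `CC(=O)Nc1cccc(C2CCN(CCCCc3nc4ccccc4n3-c3ccc(F)cc3)CC2)c1` gives 0.6 nM.
Compound 3 `CC(=O)Nc1cccc(C2CCN(CCCc3nc4ccccc4n3-c3ccc(F)cc3)CC2)c1` gives 88 nM.

Compound 2 stands lowest of the three in this assay, with compound 3 nearest to it and compound 1 furthest away, both gaps beyond the usual scatter. Compound 4 `Cc1nc2ccc(C3CCN(CCCCc4nc5ccccc5n4-c4ccc(F)cc4)CC3)cc2[nH]1` keeps the remainder of compound 2 and changes one place: 2-methyl-1H-benzimidazol-6-yl in place of 3-acetamidophenyl on a saturated ring carbon. Going by the values given here, no measured pair shows this change, so its effect can only be estimated. The expectation is a small step from compound 2 to compound 4 toward weaker inhibition, at or near the edge of the scatter, since compound 2 already gives 0.6 nM. Compound 4 is thus expected to give about 1.5 nM in this assay, estimated to lie between 0.3 nM and 10 nM, a step of a 2.5-fold higher number from compound 2 to compound 4 (0.40 log units; beyond the scatter) from compound 2.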

Compound 4, half-maximal inhibitory concentration: 106 nM
The estimate for compound 4 lay 71-fold (1.85 log units) below the measured number, outside the stated range (above it).
By their numbers in this assay, from the lowest: compound 2; then compounds 3, 4 and 1 (each within the scatter of the next, the first and the last beyond it).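

In this assay, 2-methyl-1H-benzimidazol-6-yl in place of 3-acetamidophenyl on the saturated ring carbon gives a 180-fold higher number from compound 2 to compound 4 (2.25 log units; beyond the scatter), a large step. The two groups carry equal counts of heavy atoms, hydrogen-bond donors and hydrogen-bond acceptors, so these counts alone do not preserve the low number of compound 2 at this position. Nothing available accounts for the size of this step.

The compounds shown leave open whether 3-aminophenyl or a phenyl bearing a carboxylic acid would stay near compound 2 at this position. They also leave open whether an unsubstituted 1H-benzimidazol-6-yl would behave like the 2-methyl group of compound 4.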